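A few compounds are considered here, and "the series" means these few. Any claim that something is new, unique, unknown or untested is made for them only; others in the source may bear on it.

Of the compounds shown here, three sharing one core have been measured in a functional assay on HT-29 cells (Homo sapiens) for inhibition, read by MTT assay, with a stated time of 72 h; a higher number here means a weaker inhibitor of growth, a lower number a stronger inhibitor of growth. Compound 1 `CC(C)(C)c1ccc(CNCCCNS(=O)(=O)c2cc(C(F)(F)F)cc(C(F)(F)F)c2)cc1` gives 2000 nM, compound 2 `COc1ccc(CNCCCNS(=O)(=O)c2cc(C(F)(F)F)cc(C(F)(F)F)c2)cc1OC` gives 2700 nM, and compound 3 `O=S(=O)(NCCCNCc1cccc(Cl)c1)c1cc(C(F)(F)F)cc(C(F)(F)F)c1` gives 14000 nM. Compound 3 thus stands highest of the three numbers: the step of a 7.0-fold higher number from compound 1 to compound 3 (0.85 log units; beyond the scatter) and the step of a 5.2-fold higher number from compound 2 to compound 3 (0.71 log units; beyond the scatter) both lie beyond the scatter, whereas the step of a 1.4-fold higher number from compound 1 to compound 2 (0.13 log units; within the scatter) lies within it, so the 4-(tert-butyl)phenyl and 3,4-dimethoxyphenyl groups cannot be ranked against each other on these numbers.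

Compound 4 `COc1ccccc1CNCCCNS(=O)(=O)c1cc(C(F)(F)F)cc(C(F)(F)F)c1` has not yet been measured in this assay. It differs from compound 3 in one place: 2-methoxyphenyl in place of 3-chlorophenyl on a saturated chain carbon bound to an amine nitrogen. Within the data shown here, the steps that bear on this change are the two that arrive at 3-chlorophenyl from another aryl group; both were modest and both ran toward a higher number. The step of a 5.2-fold higher number from compound 2 to compound 3 (0.71 log units; beyond the scatter) is the closer comparison, a methoxy-bearing ring set against the chlorophenyl. Reversing such a step, compound 4 is expected to show a modest move to a lower number, a 2.8-fold lower number from compound 3 to compound 4 (0.45 log units; beyond the scatter). The estimate for compound 4 in this assay is 5000 nM, with a range from 2000 nM to 14000 nM.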

Compound 4, concentration for 50% growth inhibition: 12000 nM
For compound 4 the middle estimate is 2.4-fold (0.38 log units) below the measured one, and the stated range covers the measured number.
By their numbers in this assay, from the lowest: compounds 1 and 2 (each within the scatter of the next); then compounds 4 and 3 (each within the scatter of the next).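

In this assay, exchanging 3-chlorophenyl for 2-methoxyphenyl on a saturated chain carbon bound to an amine nitrogen gives a 1.2-fold lower number from compound 3 to compound 4 (0.07 log units; within the scatter), so these two groups cannot be ranked against each other, and the methoxy-bearing ring of compound 4 does not share the lower number of the methoxy-bearing ring of compound 2. The other two steps confirm this, with a 4.4-fold higher number from compound 2 to compound 4 (0.65 log units; beyond the scatter) and a 6.0-fold higher number from compound 1 to compound 4 (0.78 log units; beyond the scatter), so the four aryl groups now fall into two pairs: 4-(tert-butyl)phenyl with 3,4-dimethoxyphenyl at the lower numbers, and 3-chlorophenyl with 2-methoxyphenyl at the higher ones. Nothing available accounts for this division of the four groups.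

The compounds shown leave open how 4-methoxyphenyl, 4-chlorophenyl or an unsubstituted phenyl ring would read here, and so whether the division follows the identity of the group or where it stands on the ring. Also open, as far as these compounds go, is how far the numbers would move with a longer chain or with an amide in place of the amine, as all four compounds share the same chain and amine nitrogen.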